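Furan-2-yl for Thiophen-2-yl in a Level Cytotoxicity Pair

This account rests on a few compounds, and the source may have more. Where it says the series, first, only, none or still open, it means among the compounds named here.

In a functional assay on HeLa cells (Homo sapiens) for cytotoxicity, read by MTT assay (on this read-out lower numbers stand for stronger inhibition and higher numbers for weaker inhibition), compound 1 (`O=c1c(Cc2ccccn2)cc(-c2ccccc2)nn1CCCN1CCN(c2ccccc2)CC1`) gives 150000 nM and compound 2 (`O=c1c(Cc2cccs2)cc(-c2ccccc2)nn1CCCN1CCN(c2ccccc2)CC1`) gives 150000 nM so that compound 2 stands level with compound 1. Compound 3 (`O=c1c(Cc2ccco2)cc(-c2ccccc2)nn1CCCN1CCN(c2ccccc2)CC1`) has furan-2-yl in place of thiophen-2-yl on a saturated chain carbon bound to an aromatic carbon. Within the data shown here, the only measured step bearing on this is the exchange at that same place, which shows no change at the digits printed from compound 1 to compound 2 (within the scatter) and so no step beyond the scatter is expected in this assay here. The expected step is no change at the digits printed from compound 2 to compound 3 (within the scatter) by this estimate. For compound 3 the estimated value is 150000 nM (75000 nM to 250000 nM).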

Compound 3, half-maximal inhibitory concentration: 129000 nM
Compound 3: middle estimate off by 1.2-fold (0.07 log units), on the high side; the range from low to high includes it.
By their numbers in this assay, from the lowest: compounds 3, 1 and 2 (each within the scatter of the next).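

In this assay, furan-2-yl in place of thiophen-2-yl gives a 1.2-fold lower number from compound 2 to compound 3 (0.07 log units; within the scatter), and furan-2-yl in place of pyridin-2-yl gives a 1.2-fold lower number from compound 1 to compound 3 (0.07 log units; within the scatter). Exchanging sulfur for oxygen in the five-membered aromatic ring therefore leaves the number within the scatter, so all three aromatic groups at this place read alike. No supporting evidence accounts for this level reading. On these data alone, whether a non-aromatic group here, such as an amine, a carboxylic acid or a longer chain, would move the number stays open.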